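The source may hold more compounds than are shown below. What is called first, only, known or untested is meant among the compounds shown, and "the series" means these compounds.

Measured compounds:
- compound 1, `Cc1c(C(=O)/C=C/c2ccc(Cl)c(Cl)c2)[n+]([O-])c2ccccc2[n+]1[O-]`: 10100 nM
- compound 2, `COc1cc(/C=C/C(=O)c2c(C)[n+]([O-])c3ccccc3[n+]2[O-])cc(OC)c1OC`: 5510 nM

Both compounds were tested in a functional assay on MOLT-4 cells (Homo sapiens) for inhibition, with a stated time of 3 days; a higher number here means a weaker inhibitor, a lower number a stronger inhibitor. Compound 1 gives 10100 nM in this assay, and compound 2 gives 5510 nM. These two values lie within the usual scatter of one another, so compound 1 cannot be set apart from compound 2 on these numbers; the two compounds simply sit together at the weak end of what has been measured.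

Compound 3, `Cc1c(C(=O)/C=C/c2ccc(Br)cc2)[n+]([O-])c2ccccc2[n+]1[O-]`, has not yet been measured in this assay. It differs from compound 1 in one place: 4-bromophenyl in place of 3,4-dichlorophenyl on a double-bonded chain carbon bound to a double-bonded chain carbon. Within the data shown here, no pair of measured compounds shows what this kind of exchange does in this assay, so there is no measured step to lean on. Compound 2 differs from compound 1 in the same region of the molecule and lands within the scatter of compound 1, which suggests that changes here have not so far moved the number much.

The step from compound 1 to compound 3 is therefore expected to be small, a 1.1-fold lower number from compound 1 to compound 3 (0.05 log units; within the scatter), not clearly beyond the scatter in either direction. Compound 3 is estimated to give 9000 nM in this assay, with a likely range from 3000 nM to 30000 nM.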

Compound 3, half-maximal inhibitory concentration: 17100 nM
The estimate for compound 3 lay 1.9-fold (0.28 log units) below the measured number; the measured number falls inside the stated range.
By their numbers in this assay, from the lowest: compounds 2, 1 and 3 (each within the scatter of the next, the first and the last beyond it).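

In this assay, among these compounds, the exchange of 3,4-dichlorophenyl for 4-bromophenyl on a double-bonded chain carbon bound to a double-bonded chain carbon gives the first measured step at this place: a 1.7-fold higher number from compound 1 to compound 3 (0.23 log units; within the scatter). The two groups therefore cannot be told apart on this read-out, even though the exchange replaces two chlorine atoms with one bromine atom and takes the group from 8 heavy atoms to 7. No independent measurement bears on this result, so the step stands as a number with no explanation attached.

The compounds shown leave open whether any group at this place can move the number clearly beyond the scatter, for instance a phenyl ring carrying an amine or a carboxylic acid in place of the chlorine or bromine atoms. They also leave open what a change elsewhere on the shared core would do, such as a longer chain in place of the methyl group, since all three compounds carry that methyl group unchanged.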